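The source may report more compounds than this note shows. Statements on the series, on what has been measured and on what is new or still open speak of the compounds shown alone.

Measured in a functional assay on PC-3 cells (Homo sapiens) for antiproliferative activity, read by MTT assay, with a stated time of 24 h; on this read-out lower numbers stand for stronger inhibition and higher numbers for weaker inhibition:

Compound 1 `CCN(CC)CCNC(=O)c1ccc(C(CC)(CC)c2ccc(OCS(=O)(=O)c3ccccc3)c(C)c2)n1CC` gives 7130 nM.
Compound 2 `CCn1c(C(=O)N[C@@H](C)CO)ccc1C(CC)(CC)c1ccc(OCS(=O)(=O)c2ccccc2)c(C)c1` gives 9520 nM.
Compound 3 `CCn1c(C(=O)NCCO)ccc1C(CC)(CC)c1ccc(OCS(=O)(=O)c2ccccc2)c(C)c1` gives 17700 nM.

Compound 1 stands at the lowest number of the three; its nearest neighbour is compound 2, its furthest compound 3. Compound 4 `CCn1c(C(=O)N[C@@H](CO)CCO)ccc1C(CC)(CC)c1ccc(OCS(=O)(=O)c2ccccc2)c(C)c1` has not yet been measured in this assay. It differs from compound 1 in one place: 3-hydroxy-1-(hydroxymethyl)propyl in place of 2-(diethylamino)ethyl on an amide-type nitrogen.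

Among the measured compounds shown here, two measured steps bear on this change, both replacing the same 2-(diethylamino)ethyl group at the same amide-type nitrogen by a hydroxy-bearing chain. The first, a 1.3-fold higher number from compound 1 to compound 2 (0.13 log units; within the scatter), stays within the scatter. The second, a 2.5-fold higher number from compound 1 to compound 3 (0.39 log units; beyond the scatter), goes beyond it, in the direction of a higher number. Between those two products, a 1.9-fold higher number from compound 2 to compound 3 (0.27 log units; within the scatter) lies within the scatter. The group entering in compound 4 carries two hydroxy groups rather than one, and the measured steps give no case of such a group at this position; the expectation therefore rests on the two single-hydroxy replacements, which point the same way.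

For compound 4 a step of about a 2.1-fold higher number from compound 1 to compound 4 (0.32 log units; beyond the scatter) is expected, toward a higher number, because both a 1.3-fold higher number from compound 1 to compound 2 (0.13 log units; within the scatter) and a 2.5-fold higher number from compound 1 to compound 3 (0.39 log units; beyond the scatter) went that way. The estimate for compound 4 in this assay is 15000 nM, within a range of 7500 nM to 30000 nM.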

Compound 4, half-maximal inhibitory concentration: 14100 nM
Compound 4: middle estimate off by 1.1-fold (0.03 log units), on the high side; low and high end bracket the measured number.
By their numbers in this assay, from the lowest: compounds 1, 2, 4 and 3 (each within the scatter of the next, the first and the last beyond it).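

In this assay, among the compounds shown here, the 3-hydroxy-1-(hydroxymethyl)propyl group on the amide-type nitrogen replaces 2-(diethylamino)ethyl with a 2.0-fold higher number from compound 1 to compound 4 (0.30 log units; within the scatter), so this two-hydroxy replacement, like the single-hydroxy one in compound 2, stays within the scatter, and compound 3 remains the only compound whose number lies beyond the scatter from that of compound 1. Among the hydroxy-bearing amides, adding 2-hydroxyethyl to the saturated chain carbon gives a 1.3-fold lower number from compound 3 to compound 4 (0.10 log units; within the scatter), and the change from 1-(hydroxymethyl)ethyl to the larger group gives a 1.5-fold higher number from compound 2 to compound 4 (0.17 log units; within the scatter), so compounds 2, 3 and 4 are not separated from one another at this position, despite the difference in hydroxy count. No supporting measurement bears on why the numbers fall as they do.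

Still open, on these data alone, is how a carboxylic acid or a morpholine on the chain at this amide-type nitrogen would read in this assay, and whether a longer chain ending in diethylamino would stay near compound 1 at 7130 nM on this read-out. As far as these compounds go, the opposite configuration at the defined stereocentre of 3-hydroxy-1-(hydroxymethyl)propyl is also open.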